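The source may report more compounds than this note shows. Statements on the series, on what has been measured and on what is new or still open speak of the compounds shown alone.

Measured compounds in a functional assay on SW480 cells (Homo sapiens) for cytotoxicity, read by MTT assay, with a stated time of 4 days; a higher number here means a weaker inhibitor, a lower number a stronger inhibitor:
- compound 1, `C=C1C[C@]23C[C@@]1(O)CC[C@@H]2c1cccc(C)c1[C@@H]3Cn1cc(-c2ccc(C)cc2)nn1` — > 20000 nM
- compound 2, `C=C1C(=O)[C@]23C[C@@]1(O)CC[C@H]2c1ccc(O)c(C)c1[C@@H]3Cn1cc(-c2ccc(Br)cc2)nn1` — 310 nM
- compound 3, `C=C1C(=O)[C@]23C[C@@]1(O)CC[C@H]2c1ccc(OS(=O)(=O)c2ccc(C)cc2)c(C)c1[C@@H]3Cn1cc(-c2ccc(Br)cc2)nn1` — 1590 nM

Compound 1 gives only a limit in this assay, (the limit of > 20000 nM in this assay, at which 1 of the 3 values shown sits), not a number. Compound 2 holds the lowest of the two numbers in this assay; its nearest neighbour is compound 3, reached by the step of a 5.1-fold higher number from compound 2 to compound 3 (0.71 log units; beyond the scatter), which puts (4-methylphenyl)sulfonyl in place of hydrogen on an oxygen on an aromatic ring.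

The compound still to be measured is compound 4, `C=C1C(=O)[C@]23C[C@@]1(O)CC[C@H]2c1ccc(O)c(C)c1[C@@H]3Cn1cc(-c2ccc(F)cc2)nn1`. It differs from compound 2 in one place: fluoro in place of bromo on an aromatic carbon. Within the data shown here, this is a change on the 4-bromophenyl group carried by the triazole, and none of the measured steps touches that group. Among the measured compounds shown here, the one measured step, from compound 2 to compound 3, alters a different part of the shared core, so it gives no direct guide to exchanging one halogen for another. For the measured compounds named here, with no comparable step available, the expectation for compound 4 rests on the small size of the change alone: a step of a 1.9-fold higher number from compound 2 to compound 4 (0.29 log units; within the scatter) is expected, lying within or just beyond the scatter. Compound 4 is therefore estimated to give about 600 nM in this assay, with a range from 200 nM to 2500 nM.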

Compound 4, half-maximal inhibitory concentration: 250 nM
Beside the measured number, compound 4's estimate is 2.4-fold (0.38 log units) above it; low and high end bracket the measured number.
By their numbers in this assay, from the lowest: compounds 4 and 2 (each within the scatter of the next); then compound 3. At a limit, above all of these: compound 1.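

In this assay, among these compounds, the exchange of 4-bromophenyl to 4-fluorophenyl is the first measured change on the group carried by the triazole, and it reads as a 1.2-fold lower number from compound 2 to compound 4 (0.09 log units; within the scatter). At this place, para to a large group, the two halogens therefore cannot be told apart in this assay, whereas the change on the oxygen on the aromatic ring reads as a 5.1-fold higher number from compound 2 to compound 3 (0.71 log units; beyond the scatter), so the number does not respond to every edit of these molecules in the same way. Nothing in the data available bears on why the bromo and fluoro compounds read alike.

On these data alone, both halogens count as a single heavy atom, so it remains open whether the same place would accept something quite different, such as an amine, a carboxylic acid or a longer chain in place of the halogen. Compound 1 gives > 20000 nM, which is a limit, and it differs from compound 2 in more than one place, so it cannot settle that question.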